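Thiophene amine series: phenyl for bromo, level throughout

The source may hold more compounds than are shown below. What is called first, only, known or untested is meant among the compounds shown, and "the series" means these compounds.

The shared core is a five-membered aromatic ring with one sulfur carrying an amino group and a ketone to a chlorophenyl, varied at the ring carbon bound to the sulfur and at the alkyl group on the ring. Compound 2 `Cc1c(Br)sc(N)c1C(=O)c1ccc(Cl)cc1` carries a bromo and a methyl group. In an assay on CHO cells for displacement of a labelled ligand from adenosine receptor A3 (Homo sapiens), read by scintillation counting, tested at 10 uM (a lower number here means less inhibition, a higher number more inhibition at the concentration tested (going by the name of the read-out)), compound 2 gives 1%. Compound 1 `Cc1c(-c2ccccc2)sc(N)c1C(=O)c1ccc(Cl)cc1` differs from compound 2 by phenyl in place of bromo on an aromatic carbon, and in this assay compound 1 gives 1%; the step of no change at the digits printed from compound 2 to compound 1 (within the scatter). Compound 3 `CC(C)(C)Cc1c(Br)sc(N)c1C(=O)c1ccc(Cl)cc1` differs from compound 2 by tert-butyl in place of hydrogen on a saturated chain carbon bound to an aromatic carbon, and in this assay compound 3 gives 1%; the step of no change at the digits printed from compound 2 to compound 3 (within the scatter). All three sit together at the digits printed.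

Compound 4 `CC(C)(C)Cc1c(-c2ccccc2)sc(N)c1C(=O)c1ccc(Cl)cc1` is not yet measured. It differs from compound 3 by phenyl in place of bromo on an aromatic carbon. This is the same kind of change as from compound 2 to compound 1, but not the same: in that pair the place is next to the ring atom that bears a methyl group, whereas here it is next to the ring atom that bears a neopentyl group. The two cores differ by tert-butyl in place of hydrogen on a saturated chain carbon bound to an aromatic carbon.

With the earlier step flat and every number in the set level, the expected step of a number 1 percentage points higher from compound 3 to compound 4 (within the scatter) is also flat, because no change at the digits printed from compound 2 to compound 1 (within the scatter) and no change at the digits printed from compound 2 to compound 3 (within the scatter) both stayed within the scatter. Compound 4 is estimated at 2%, between 0% and 12%.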

Compound 4, a percentage reported as inhibition, at one concentration (the size of the read-out at that concentration, not a potency): 1%
The estimate for compound 4 lay 1 percentage points above the measured number; the measured number falls inside the stated range.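

In this assay, phenyl in place of bromo on the core bearing a neopentyl group shows no change at the digits printed from compound 3 to compound 4 (within the scatter), and this step agrees with the same change on the core bearing a methyl group: the same change on two cores in this assay, no change at the digits printed (within the scatter) from compound 2 to compound 1 and no change at the digits printed (within the scatter) from compound 3 to compound 4, 0 percentage points apart, within the scatter of two such steps
Tert-butyl in place of hydrogen on the saturated chain carbon shows no change at the digits printed from compound 1 to compound 4 (within the scatter), and this step also agrees with its earlier counterpart: the same change on two cores in this assay, no change at the digits printed (within the scatter) from compound 2 to compound 3 and no change at the digits printed (within the scatter) from compound 1 to compound 4, 0 percentage points apart, within the scatter of two such steps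
The two changes therefore combine without any sign of dependence on the core, but all four compounds sit level at a very low inhibition, so this is agreement between flat steps only and does not show that a step of measurable size would carry from one core to another, nor does a reading at a single concentration give any potency.

The compounds shown leave open whether any group on the aromatic carbon next to the ring sulfur would raise the read-out above this level, for example an amine or a carboxylic acid in place of the bromo or phenyl group. Also open, on these data alone, is how a longer chain in place of the neopentyl group, or a methoxy group in place of the chloro group on the phenyl ketone, would read in this assay.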